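The compounds below may be only part of what the source reports. "The series", "measured", "known", "first", "only" and "open" are said of these compounds alone.

Measured in a functional assay on SK-OV-3 cells (Homo sapiens) for antiproliferative activity, read by MTT assay, with a stated time of 24 h; a higher number here means a weaker inhibitor, a lower number a stronger inhibitor:
- Compound 1 `COc1ccc(C(=O)/C=C/c2ccc(-c3ccccc3)cc2)c2c1C=CC(C)(C)O2`: > 10000 nM
- Compound 2 `CCN(CC)c1ccc(/C=C/C(=O)c2ccc(OC)c3c2OC(C)(C)C=C3)cc1`: 610 nM
- Compound 3 `COc1ccc(C(=O)/C=C/c2ccc([N+](=O)[O-])cc2)c2c1C=CC(C)(C)O2`: 3420 nM

The entry for compound 1 is a limit of the assay and not a number. Of the two true numbers, compound 3 holds the higher, so it is the weaker of those two inhibitors in this assay.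

Compound 4 `COc1ccc(C(=O)/C=C/c2ccccc2)c2c1C=CC(C)(C)O2` carries hydrogen in place of nitro on an aromatic carbon.

Three measured steps change this same carbon. They are a 5.6-fold higher number from compound 2 to compound 3 (0.75 log units; beyond the scatter), which is modest, an at least 2.9-fold lower number from compound 1 to compound 3 (0.46 log units; beyond the scatter), at least modest, and an at least 16-fold lower number from compound 1 to compound 2 (1.21 log units; beyond the scatter), which is large. Starting from compound 3, the diethylamino group gives a lower number and the phenyl group a higher one, so these steps set no direction for the loss of nitro. Among the compounds with values here, no measured compound has hydrogen at this carbon. A step of modest size at most is therefore expected, possibly none beyond the scatter, with no firm direction.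

The expected change is a 1.2-fold higher number from compound 3 to compound 4 (0.07 log units; within the scatter).

For compound 4 the estimated value is 4000 nM, with an expected range from 1300 nM to 10000 nM.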

Compound 4, half-maximal inhibitory concentration: > 10000 nM
Compound 4: a limit, no number; the forecaster's own chance of this, stated with the estimate: 20%; middle value at least 2.5-fold (0.39 log units) from the limit.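

In this assay compound 4 gives > 10000 nM as a limit of the assay, not a number. Hydrogen in place of nitro gives an at least 2.9-fold higher number from compound 3 to compound 4 (0.46 log units; beyond the scatter) and hydrogen in place of diethylamino gives an at least 16-fold higher number from compound 2 to compound 4 (1.21 log units; beyond the scatter) at this carbon, so the loss of nitro now has a direction that the earlier steps did not set: among these compounds, only those with nitro or diethylamino here give true numbers. The step between compound 1 and compound 4 cannot be read, since both stand at the same limit: the limit of > 10000 nM in this assay, at which 2 of the 4 values shown sit.

Going by these compounds, whether a methoxy group, a dimethylamino group or a carboxylic acid at this carbon would also give a true number stays open. So does any order between phenyl and hydrogen here.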